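Furan for Benzofuran on a Nucleoside Core: Compound 4

This account rests on a few compounds, and the source may have more. Where it says the series, first, only, none or still open, it means among the compounds named here.

The series gathers four nucleoside analogues tested for growth inhibition of colon carcinoma cells. Compound 1 `Cc1nc(N)c2c(-c3ccco3)cn([C@@H]3O[C@H](CO)[C@@H](O)[C@H]3O)c2n1` and compound 2 `Cc1nc(N)c2c(-c3cc4ccccc4o3)cn([C@@H]3O[C@H](CO)[C@@H](O)[C@H]3O)c2n1` share one core, while compound 3 `CNc1ncnc2c1c(-c1cc3ccccc3o1)cn2[C@@H]1O[C@H](CO)[C@@H](O)[C@H]1O` and compound 4 `CNc1ncnc2c1c(-c1ccco1)cn2[C@@H]1O[C@H](CO)[C@@H](O)[C@H]1O` share another; the difference between the two cores is not broken down here.

In a functional assay on HCT-116 cells (Homo sapiens), read by MTT assay, with a stated time of 72 h (on this read-out higher numbers stand for weaker inhibition and lower numbers for stronger inhibition), compound 2 gives 13100 nM. For compound 1 the result in this assay is a limit of the assay, > 20000 nM. For compound 3 the result in this assay is likewise a limit, > 20000 nM. The step from compound 2 to compound 1 is described by furan-2-yl in place of 1-benzofuran-2-yl on an aromatic carbon and amounts to an at least 1.5-fold higher number from compound 2 to compound 1 (0.18 log units; that floor lies within the scatter); it leads onto (the limit of > 20000 nM in this assay, at which 2 of the 3 values shown sit), so its true size is not resolved.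

The same change is made from compound 3 to compound 4, (furan-2-yl in place of 1-benzofuran-2-yl on an aromatic carbon), and the surrounding place is the same in both pairs. Since compound 3 already sits at the limit > 20000 nM, and since the same exchange did not lower the number from compound 2 to compound 1, the step from compound 3 to compound 4 is expected to be about a step that the limit leaves unreadable from compound 3 to compound 4, with the measurement most likely reported again as a limit. Compound 4 is therefore estimated to give roughly 40000 nM in this assay, expected to lie between 15000 nM and 120000 nM.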

Compound 4, half-maximal inhibitory concentration: 440 nM
For compound 4 the middle estimate is 91-fold (1.96 log units) above the measured one; the measured number lies below the stated range.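

In this assay, furan-2-yl in place of 1-benzofuran-2-yl gives an at least 45-fold lower number from compound 3 to compound 4 (1.65 log units; beyond the scatter), whereas the same change gives an at least 1.5-fold higher number from compound 2 to compound 1 (0.18 log units; that floor lies within the scatter), so in this series the change does not carry from one core to the other with the same size, and the two cores give results that differ clearly: the same change on two cores in this assay, an at least 1.5-fold higher number (0.18 log units; that floor lies within the scatter) from compound 2 to compound 1 and an at least 45-fold lower number (1.65 log units; beyond the scatter) from compound 3 to compound 4, at least 69-fold (1.84 log units) apart, beyond the scatter of two such steps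

Neither step has a true size that can be read, however, as each has one end at a limit of the assay, so the gap between them is only a minimum: the limit of > 20000 nM in this assay, at which 2 of the 4 values shown sit.

The result shows that the effect of this exchange depends on the core in these two pairs, but it does not show which feature of the core is responsible, and two pairs support no general rule for the series.

The compounds shown leave open which part of the difference between the two cores separates the two outcomes, as the cores are not compared here through any pair that differs in one place. They also leave open whether a phenyl or thiophen-2-yl group on the same aromatic carbon would follow furan-2-yl or 1-benzofuran-2-yl on either core.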